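The source may report more compounds than this note shows. Statements on the series, on what has been measured and on what is new or still open speak of the compounds shown alone.

Measured so far:

Compound 1 `CCCCOc1ccc2c(Cl)ccnc2c1`, in a functional assay on SK-OV-3 cells (Homo sapiens) for cytotoxicity, read by MTT assay, with a stated time of 48 h (a lower number here means a stronger inhibitor, a higher number a weaker inhibitor), compound 1 gives 4130 nM.
Compound 2 `CCCCCCCCOc1ccc2c(Cl)ccnc2c1`, in this assay compound 2 gives 4300 nM.
Compound 3 `CCOc1ccc2c(NCCN(C)C)ccnc2c1`, in this assay compound 3 gives 4620 nM.

The three values sit close together; compound 3 is not separated from the others by more than the usual scatter. The difference between the core of compound 1 and the core of compound 3 is not broken down here.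

Compound 2 arises from compound 1 by butyl in place of hydrogen on a saturated chain carbon, four bonds along the chain from an oxygen on an aromatic ring and gives a 1.0-fold higher number from compound 1 to compound 2 (0.02 log units; within the scatter).

Compound 4 `CCCCCCOc1ccc2c(NCCN(C)C)ccnc2c1` is not yet measured. It arises from compound 3 by butyl in place of hydrogen on a saturated chain carbon, two bonds along the chain from an oxygen on an aromatic ring. This is the same kind of change as that from compound 1 to compound 2, but the place differs: two bonds along the chain from an oxygen on an aromatic ring here, against four bonds there.

Beside the flat step seen from compound 1 to compound 2, the expected step of a 1.0-fold higher number from compound 3 to compound 4 (0.01 log units; within the scatter) from compound 3 to compound 4 in this assay is likewise small, resting on compound 3 giving 4620 nM and on the earlier step of a 1.0-fold higher number from compound 1 to compound 2 (0.02 log units; within the scatter). For compound 4 the estimate in this assay is 4700 nM, expected between 2000 nM and 11000 nM.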

Compound 4, half-maximal inhibitory concentration: 1860 nM
The estimate for compound 4 lay 2.5-fold (0.40 log units) above the measured number, outside the stated range (below it).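

In this assay, butyl in place of hydrogen gives a 2.5-fold lower number from compound 3 to compound 4 (0.40 log units; beyond the scatter). The earlier step on the other core is not separated from this one: the same change on two cores in this assay, a 1.0-fold higher number (0.02 log units; within the scatter) from compound 1 to compound 2 and a 2.5-fold lower number (0.40 log units; beyond the scatter) from compound 3 to compound 4, 2.6-fold (0.41 log units) apart, within the scatter of two such steps. This gives no ground for saying that the change behaves differently on the two cores, but it does not show that the change carries over unchanged, as each core supplies a single pair and the place differs, two bonds along the chain from an oxygen on an aromatic ring here against four bonds there.

Still open, going by these compounds, is whether a longer chain, such as octyloxy, on the core of compound 3 would extend the step. Also open, on these data alone, is whether a cyclic amine in place of the dimethylamino group would leave it intact.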